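The source may hold more compounds than are shown below. What is called first, only, known or untested is meant among the compounds shown, and "the series" means these compounds.

Measured so far in a functional assay on PC-3 cells (Homo sapiens) for cytotoxicity, read by sulforhodamine B assay, with a stated time of 48 h; a higher number here means a weaker inhibitor, a lower number a stronger inhibitor:
compound 1 `C[C@H]1CC[C@@H]2[C@@H](OC(=O)[C@]23CC(c2ccc([N+](=O)[O-])cc2)=NO3)[C@]2(C)C(=O)C=C[C@@]12O` gives 12000 nM;
compound 2 `C[C@H]1CC[C@@H]2[C@@H](OC(=O)[C@]23CC(c2ccccc2F)=NO3)[C@]2(C)C(=O)C=C[C@@]12O` gives 8200 nM.

Compound 2 has the lowest of the two numbers in this assay, with compound 1 a step away that is within the scatter. Compound 3 `Cc1ccccc1C1=NO[C@]2(C1)C(=O)O[C@@H]1[C@H]2CC[C@H](C)[C@]2(O)C=CC(=O)[C@@]12C` differs from compound 2 by methyl in place of fluoro on an aromatic carbon. Among the measured compounds shown here, the only measured step, a 1.5-fold lower number from compound 1 to compound 2 (0.17 log units; within the scatter), changes the substituent on the same aryl ring and stays within the scatter, so a change of this kind gives no ground to expect a shift beyond the scatter. For compound 3 the estimate is 8000 nM, range 3000 nM to 20000 nM, which is an expected step of a 1.0-fold lower number from compound 2 to compound 3 (0.01 log units; within the scatter).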

Compound 3, half-maximal inhibitory concentration: 10000 nM
Compound 3: the middle estimate sits 1.3-fold (0.10 log units) below what was measured; low and high end bracket the measured number.
By their numbers in this assay, from the lowest: compounds 2, 3 and 1 (each within the scatter of the next).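

Read in this assay, methyl in place of fluoro on this aromatic carbon gives a 1.2-fold higher number from compound 2 to compound 3 (0.09 log units; within the scatter) and leaves the two groups unseparated. The step of a 1.2-fold lower number from compound 1 to compound 3 (0.08 log units; within the scatter) shows the same for 2-methylphenyl in place of 4-nitrophenyl, so all three aryl groups on the shared core now lie within the scatter of each other. No supporting data bear on this result. Still open, from the compounds shown here alone, is whether an amine or a carboxylic acid on this aromatic ring, or a longer chain in place of methyl, would give a step beyond the scatter.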